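This account rests on a few compounds, and the source may have more. Where it says the series, first, only, none or still open, it means among the compounds named here.

Measured so far in a functional assay on NCI-H460 cells (Homo sapiens) for inhibition, read by sulforhodamine B assay, with a stated time of 48 h; a higher number here means a weaker inhibitor of growth, a lower number a stronger inhibitor of growth:

compound 1 `CC1=CC[C@H](C(C)(C)NC(=S)N/N=C/c2ccccc2)CC1` gives 13000 nM
compound 2 `CC1=CC[C@H](C(C)(C)NC(=S)N/N=C/c2ccc(F)cc2)CC1` gives a limit of the assay, > 100000 nM
compound 3 `CC1=CC[C@H](C(C)(C)NC(=S)N/N=C/c2ccc(Cl)cc2)CC1` gives 7800 nM

Compound 3 has the lowest of the two numbers, with compound 1 nearest: a 1.7-fold lower number from compound 1 to compound 3 (0.22 log units; within the scatter). Compound 2 sits at a limit (the limit of > 100000 nM in this assay, at which 1 of the 3 values shown sits). The step reaching that limit is an at least 7.6-fold higher number from compound 1 to compound 2 (0.88 log units; beyond the scatter), while the step away from it is an at least 12-fold lower number from compound 2 to compound 3 (1.10 log units; beyond the scatter).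

Compound 4 `CC1=CC[C@H](C(C)(C)NC(=S)N/N=C/c2ccc[nH]2)CC1` differs from compound 3 in one place: 1H-pyrrol-2-yl in place of 4-chlorophenyl on a carbon with a double bond to nitrogen. The three measured steps all concern a change on the same aromatic ring: a chloro left the number about where it was in compound 1, a fluoro sent it past the assay limit, and the chloro-for-fluoro exchange gave a large drop. None of them swaps the whole ring for a five-membered ring bearing a nitrogen, so they only show that this position is sensitive. Compound 4 is therefore expected to give a higher number than compound 3, roughly a 1.9-fold higher number from compound 3 to compound 4 (0.28 log units; within the scatter), an estimate of 15000 nM in this assay with a range from 4000 nM to 60000 nM.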

Compound 4, concentration for 50% growth inhibition: 18000 nM
The estimate for compound 4 lay 1.2-fold (0.08 log units) below the measured number, and the stated range covers the measured number.
By their numbers in this assay, from the lowest: compounds 3, 1 and 4 (each within the scatter of the next, the first and the last beyond it). At a limit, above all of these: compound 2.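

Swapping the whole ring, and not just a substituent on it, is tolerated at this position: 1H-pyrrol-2-yl in place of phenyl gives a 1.4-fold higher number from compound 1 to compound 4 (0.14 log units; within the scatter) and so does about as well as the plain phenyl, despite being a smaller ring that carries a hydrogen-bond donor. The 4-chlorophenyl group does keep a real edge over the new ring, with a 2.3-fold higher number from compound 3 to compound 4 (0.36 log units; beyond the scatter) as the step. The five-membered ring also reads clearly better than 4-fluorophenyl, with an at least 5.5-fold lower number from compound 2 to compound 4 (0.74 log units; beyond the scatter) as the step, though this is only a bound, as compound 2 stands at a limit: the limit of > 100000 nM in this assay, at which 1 of the 4 values shown sits.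

The compounds shown do not tell whether the hydrogen on the pyrrole nitrogen matters, which a 1-methylpyrrol-2-yl group would test. Nor do they show how a furan-2-yl or pyridin-2-yl ring, or an amine on the phenyl ring, would behave here.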